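The compounds below may be only part of what the source reports. "The series", "measured", "known", "first", "only" and "open" are said of these compounds alone.

Compound 1 (`Cc1nc(-c2cc(C(F)(F)F)ccc2[C@H]2CCOc3cc(S(=O)(=O)Nc4ccncn4)ccc32)co1`) carries a 2-methyl-1,3-oxazol-4-yl group on the shared core. In a physicochemical assay for lipophilicity (a higher number here means a more lipophilic compound, a lower number a more polar compound), compound 1 is reported as "not determined" (no result reported) and so offers no number of its own as a starting point. Its nearest measured relatives keep the same group and differ on the sulfonamide nitrogen: compound 2 (`Cc1nc(-c2cc(C(F)(F)F)ccc2[C@H]2CCOc3cc(S(=O)(=O)Nc4cccc(F)n4)ccc32)co1`) gives 4 and compound 3 (`Cc1nc(-c2cc(C(F)(F)F)ccc2[C@H]2CCOc3cc(S(=O)(=O)Nc4nccs4)ccc32)co1`) gives 2.9 on the same read-out. Among the compounds with values here, the only measured step, a number 1.10 log units lower from compound 2 to compound 3 (beyond the scatter), is large, but it lies on the sulfonamide nitrogen.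

Compound 4 (`Cc1ccc(-c2cc(C(F)(F)F)ccc2[C@H]2CCOc3cc(S(=O)(=O)Nc4ccncn4)ccc32)cn1`) keeps the sulfonamide substituent of compound 1 and changes the other end of the molecule: 6-methylpyridin-3-yl in place of 2-methyl-1,3-oxazol-4-yl on an aromatic carbon, on an aromatic carbon of a six-membered aromatic ring of carbon only, ortho to a large group and meta to a trifluoromethyl group. Within the data shown here, no measured step touches this place, so that large step cannot be carried over to it. No step beyond the scatter is expected in this assay, and no direction can be argued from the data. With compound 1 lacking a number, the expectation is anchored near compound 3 at 2.9, with a wide margin. Compound 4 is estimated at 3.1, with an expected range from 2.4 to 3.8 for repeated measurements.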

Compound 4, distribution coefficient: 3
Estimate against measurement, compound 4: 0.10 log units above, and the stated range covers the measured number.
By their numbers in this assay, from the lowest: compounds 3 and 4 (each within the scatter of the next); then compound 2.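

In this assay, within the data shown here, compound 1 stands as "not determined" (no result reported) and so no step from it to compound 4 can be read. The compounds shown leave open how 6-methylpyridin-3-yl and 2-methyl-1,3-oxazol-4-yl compare on the shared core with the sulfonamide substituent held fixed. Nothing in the data speaks to a cause for the result for compound 4.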